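Replacing 2-chlorophenyl with 3-fluorophenyl on a carbonyl carbon

The source may report more compounds than this note shows. Statements on the series, on what has been measured and on what is new or still open speak of the compounds shown alone.

In an ADME assay on Vero cells (Chlorocebus sabaeus) for cytotoxicity, read by MTT assay, with a stated time of 72 h (a higher number here means that more compound is needed for the effect, a lower number that less compound is needed), the compounds so far read as follows:
Compound 1 `O=C(Nc1nc(-c2ccccn2)cs1)c1ccccc1O` gives "not determined" (no result reported)
Compound 2 `O=C(Nc1nc(-c2ccccn2)cs1)c1ccccc1Cl` gives 2000 nM

Within the data shown here, compound 2 holds the only number in this small set (2000 nM) and so cannot yet be ranked against any measured neighbour. Compound 3 `O=C(Nc1nc(-c2ccccn2)cs1)c1cccc(F)c1` has not yet been measured. In compound 3, 3-fluorophenyl stands in place of 2-chlorophenyl on a carbonyl carbon (3-fluorophenyl in place of 2-chlorophenyl on a carbonyl carbon). Among the measured compounds shown here, no measured pair shows what a change at this place does in this assay and so the expectation is a step no larger than the usual scatter, with neither direction favoured. For compound 3 the estimated value is 2500 nM with an expected range from 700 nM to 10000 nM in the same read-out. The expected change is a 1.3-fold higher number from compound 2 to compound 3 (0.10 log units; within the scatter) on this estimate.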

Compound 3, half-maximal effective concentration: 1200 nM
Compound 3: the middle estimate sits 2.1-fold (0.32 log units) above what was measured; low and high end bracket the measured number.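

In this assay, the place on the carbonyl carbon now has its first measured step, with 3-fluorophenyl in place of 2-chlorophenyl giving a 1.7-fold lower number from compound 2 to compound 3 (0.22 log units; within the scatter). Compound 2 and compound 3 therefore cannot be told apart in this read-out, so this exchange of one halogen-bearing phenyl group for another leaves the number within the scatter. Nothing measured here bears on why the two compounds read as they do. Among these compounds, because these two groups differ in both the halogen and its place on the phenyl ring, the single step cannot show what either difference does alone. As far as these compounds go, it also remains open whether an amine, a carboxylic acid or a longer chain at this carbonyl carbon would move the number beyond the scatter, and compound 1 adds no value for comparison.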